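Trading a Cyclopropyl for a Propyl Chain

The compounds below may be only part of what the source reports. "The series", "measured", "known", "first", "only" and "open" are said of these compounds alone.

Compound 3 `CO[C@@H]1[C@@H](O)[C@@H](O)[C@H](Oc2ccc3cc(NC(=O)C4CC4)c(=O)oc3c2C)OC1(C)C` gives 517000 nM in a functional assay on SK-BR-3 cells (Homo sapiens) for antiproliferative activity (on this read-out higher numbers stand for weaker inhibition and lower numbers for stronger inhibition), the highest of the two numbers found. Compound 1 `CCCCCCC(=O)Nc1cc2ccc(O[C@@H]3OC(C)(C)[C@H](OC)[C@@H](O)[C@H]3O)c(C)c2oc1=O` gives 58300 nM in this assay. Compound 2 `CO[C@@H]1[C@@H](O)[C@@H](O)[C@H](Oc2ccc3cc(NC(C)=O)c(=O)oc3c2C)OC1(C)C` reaches only the limit of > 900000 nM in this assay, so no number is known for it. Compound 4 `CCCC(=O)Nc1cc2ccc(O[C@@H]3OC(C)(C)[C@H](OC)[C@@H](O)[C@H]3O)c(C)c2oc1=O` differs from compound 3 by propyl in place of cyclopropyl on a carbonyl carbon. Within the data shown here, two measured steps bear on changes at this carbonyl carbon: an 8.9-fold higher number from compound 1 to compound 3 (0.95 log units; beyond the scatter) and an at least 1.7-fold lower number from compound 2 to compound 3 (0.24 log units; that floor lies within the scatter), the second lying within the scatter. The shorter chain of compound 2 gave weaker inhibition than the hexyl of compound 1, and propyl sits between them, so a modest fall in number is expected: a 2.1-fold lower number from compound 3 to compound 4 (0.32 log units; beyond the scatter). Compound 4 is therefore estimated at 250000 nM in this assay, within a range of 80000 nM to 800000 nM.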

Compound 4, half-maximal inhibitory concentration: 313000 nM
For compound 4 the middle estimate is 1.3-fold (0.10 log units) below the measured one; the range from low to high includes it.
By their numbers in this assay, from the lowest: compound 1; then compounds 4 and 3 (each within the scatter of the next). At a limit, above all of these: compound 2.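

Swapping the ring for an open chain of the same size makes no clear difference in this assay: the result is a 1.7-fold lower number from compound 3 to compound 4 (0.22 log units; within the scatter). Chain length on this carbonyl carbon does count among the straight chains, with a 5.4-fold higher number from compound 1 to compound 4 (0.73 log units; beyond the scatter) for the change to hexyl's shorter relative and an at least 2.8-fold lower number from compound 2 to compound 4 (0.45 log units; beyond the scatter) on lengthening methyl to propyl. That second step is only a floor, since compound 2 stands at a limit of the assay: the limit of > 900000 nM in this assay, at which 1 of the 4 values shown sits.

Going by these compounds, whether a chain longer than hexyl on this carbonyl carbon would lower the number further stays open. So does the effect of an amine or a carboxylic acid in that place.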